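The source may report more compounds than this note shows. Statements on the series, on what has been measured and on what is new or still open speak of the compounds shown alone.

Of the compounds shown here, three sharing one core have been tested in a functional assay on HeLa cells (Homo sapiens) for antiproliferative activity, read by resazurin assay (a higher number here means a weaker inhibitor, a lower number a stronger inhibitor), and they differ only in the group on a sulfur. Compound 1 `Cc1ccc(C(=O)CSC(=S)SC(C)(C)C)cc1` carries tert-butyl there and gives 31600 nM. Compound 2 `Cc1ccc(C(=O)CSC(=S)SC(C)C)cc1` carries isopropyl and gives 25100 nM. Compound 3 `CSC(=S)SCC(=O)c1ccc(C)cc1` carries methyl and gives 3160 nM, the lowest number of the three and so the strongest inhibitor in this small set.

Compound 4 `Cc1ccc(C(=O)CSC(=S)SCc2ccccc2)cc1` has not yet been measured. It keeps the core of compound 3 but turns the methyl into benzyl: phenyl in place of hydrogen on a saturated chain carbon bound to a sulfur, in words phenyl in place of hydrogen on a saturated chain carbon bound to a sulfur.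

Among the measured compounds shown here, two measured steps bear on this change. Putting methyl in place of tert-butyl gave a 10-fold lower number from compound 1 to compound 3 (1.00 log units; beyond the scatter), and putting methyl in place of isopropyl gave a 7.9-fold lower number from compound 2 to compound 3 (0.90 log units; beyond the scatter). Read in reverse, both suggest that leaving methyl raises the number. The remaining step, a 1.3-fold lower number from compound 1 to compound 2 (0.10 log units; within the scatter), separates neither group from the other. For the measured compounds named here, no benzyl compound has been measured, so this reading is only a loose guide, and the step may be smaller than those two. The expected change is a 5.1-fold higher number from compound 3 to compound 4 (0.70 log units; beyond the scatter), toward a weaker inhibitor. The estimate for compound 4 is 16000 nM, with an expected range from 5000 nM to 45000 nM.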

Compound 4, half-maximal inhibitory concentration: 25100 nM
Compound 4: middle estimate off by 1.6-fold (0.20 log units), on the low side, and the stated range covers the measured number.
By their numbers in this assay, from the lowest: compound 3; then compounds 2, 4 and 1 (each within the scatter of the next).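

In this assay, among the compounds shown here, the change from methyl to benzyl brings a 7.9-fold higher number from compound 3 to compound 4 (0.90 log units; beyond the scatter) and adds the first ring to the group on this sulfur, so the rise on leaving methyl is not limited to the branched chains of compounds 1 and 2. Benzyl cannot be told apart from those branched groups, with no change at the digits printed from compound 2 to compound 4 (within the scatter) and with a 1.3-fold lower number from compound 1 to compound 4 (0.10 log units; within the scatter) as well, which leaves methyl as the only group of the four that stands apart at this position. The information available offers no explanation for why isopropyl, tert-butyl and benzyl read alike or why methyl differs.

The compounds shown leave open whether ethyl would read like methyl or like the three larger groups, so the point at which the number starts to rise remains unknown. They also leave open what a longer straight chain on this sulfur would do, and whether one ending in an amine or a carboxylic acid would bring the number back down toward that of compound 3.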